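The source may hold more compounds than are shown below. What is called first, only, known or untested is meant among the compounds shown, and "the series" means these compounds.

Measured so far in an assay on membranes from Cerebral cortex for displacement of a labelled ligand from Neuronal acetylcholine receptor; alpha4/beta2 (Rattus norvegicus); on this read-out higher numbers stand for weaker inhibition and lower numbers for stronger inhibition:
- compound 1 `O=C(Nc1ccccc1F)c1cncc(N2CC3CC(C2)N3)c1`: 0.315 nM
- compound 2 `COc1ccc(NC(=O)c2cncc(N3CC4CC(C3)N4)c2)cc1OC`: 0.828 nM

Of the two numbers in hand, compound 1 gives the lowest; the nearest is compound 2, whose value stands higher by a margin beyond the usual scatter of repeated measurements in this assay. Only these two values exist, so the series offers no guidance on how the group on the amide-type nitrogen shifts the read-out.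

Compound 3 `CCc1cccc(NC(=O)c2cncc(N3CC4CC(C3)N4)c2)c1` has not yet been measured. It differs from compound 1 in one place: 3-ethylphenyl in place of 2-fluorophenyl on an amide-type nitrogen. Going by the values given here, no measured pair traces a step of this kind, so the expected size rests on the two values shown and on the single change. The expectation is a small move towards a higher number, possibly not beyond the scatter, and the estimated step from compound 1 to compound 3 is a 1.9-fold higher number from compound 1 to compound 3 (0.28 log units; within the scatter). For compound 3 in this assay the expected value is 0.6 nM, with a plausible range from 0.2 nM to 2 nM.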

Compound 3, inhibition constant: 1.3 nM
Estimate against measurement, compound 3: 2.2-fold (0.34 log units) below; measured number inside the range.
By their numbers in this assay, from the lowest: compound 1; then compounds 2 and 3 (each within the scatter of the next).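

Going by these compounds alone, on the amide-type nitrogen, exchanging 2-fluorophenyl for 3-ethylphenyl in this assay gives a 4.1-fold higher number from compound 1 to compound 3 (0.62 log units; beyond the scatter) and thus the first readable step at this position: a modest move, but one that shows the read-out is not indifferent to this aryl group. The change stays within a narrow type of group, since both names carry a six-membered aromatic ring of carbon only, with no hydrogen-bond donors or acceptors and no net charge, so a step beyond the scatter can arise without any change in those counts. No measurement bears on the origin of this step.

Fluorine and ethyl differ in both identity and printed ring number, and this single step cannot assign the shift to either difference or to the loss of one group and the gain of the other. Unsubstituted phenyl, 3-fluorophenyl and 2-ethylphenyl on the same nitrogen would separate these contributions, while a 3-aminophenyl or 3-carboxyphenyl group would test whether an amine or a carboxylic acid is accommodated here.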